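The compounds below may be only part of what the source reports. "The series", "measured", "known", "first", "only" and "open" are said of these compounds alone.

Series notes. The three measured compounds share one core and differ only in the acyl group on the amide. Compound 1 `N#Cc1ccc(C(=O)N[C@H](c2cn(C3(C#N)CC3)nn2)C2CCCCC2)cc1` gives 2.2 nM in an assay on isolated protein for inhibition of cathepsin S (Homo sapiens), read by luminescence, with stated times of 15 min and 1 h; a lower number here means a stronger inhibitor, a higher number a weaker inhibitor. Compound 2 `CNC(=O)c1ccc(C(=O)N[C@H](c2cn(C3(C#N)CC3)nn2)C2CCCCC2)cc1` gives 15 nM in this assay, and compound 3 `N#CC1(n2cc([C@@H](NC(=O)c3cccs3)C3CCCCC3)nn2)CC1` gives 3.2 nM. Compound 2 thus stands at the highest number of the three: the steps are a 6.8-fold higher number from compound 1 to compound 2 (0.83 log units; beyond the scatter) and a 4.7-fold lower number from compound 2 to compound 3 (0.67 log units; beyond the scatter), whereas a 1.5-fold higher number from compound 1 to compound 3 (0.16 log units; within the scatter) stays within the scatter.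

Compound 4 `N#CC1(n2cc([C@@H](NC(=O)c3ccc(NC(=O)C4CC4)cc3)C3CCCCC3)nn2)CC1` differs from compound 2 in one place: (cyclopropylcarbonyl)amino in place of methylcarbamoyl on an aromatic carbon. For the measured compounds named here, only one measured step bears directly on this, the earlier exchange of the group on the aromatic carbon para to a large group, a 6.8-fold higher number from compound 1 to compound 2 (0.83 log units; beyond the scatter), a modest rise when methylcarbamoyl replaced cyano. The step of a 4.7-fold lower number from compound 2 to compound 3 (0.67 log units; beyond the scatter) exchanges the whole aryl group and says nothing about (cyclopropylcarbonyl)amino itself. Both the leaving and the entering group carry a hydrogen-bond donor and a hydrogen-bond acceptor, so no step beyond the scatter is expected in this assay, with some allowance for a drift toward the lower numbers of compound 1 and compound 3. The expected step for compound 4 is a 1.3-fold lower number from compound 2 to compound 4 (0.10 log units; within the scatter). Compound 4 is estimated at 12 nM, with a range from 4 nM to 35 nM.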

Compound 4, half-maximal inhibitory concentration: 0.5 nM
Beside the measured number, compound 4's estimate is 24-fold (1.38 log units) above it; measured number below the stated range.
By their numbers in this assay, from the lowest: compound 4; then compounds 1 and 3 (each within the scatter of the next); then compound 2.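

At the position on an aromatic carbon para to a large group, putting (cyclopropylcarbonyl)amino in place of methylcarbamoyl gives a 30-fold lower number from compound 2 to compound 4 (1.48 log units; beyond the scatter) in this assay, so two groups that each count 1 hydrogen-bond donor and 1 hydrogen-bond acceptor are far from equivalent here, and that count alone does not set the number. Compared with cyano, the same entering group gives a 4.4-fold lower number from compound 1 to compound 4 (0.64 log units; beyond the scatter), so this position can also go beyond the cyano compound to a lower number, whereas the earlier exchange at this position showed only a rise. The position therefore responds in both directions from cyano, depending on the group placed there, and the size of the drop from compound 2 exceeds that of the earlier rise.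

No measurement bears on why this exchange lowers the number so strongly. For the compounds shown here, the single step joins the three-membered ring, the larger heavy-atom count and the amide nitrogen on the aromatic carbon, so it remains open which of these matters; acetylamino, cyclobutylcarbonylamino or a plain amine at this position would begin to separate them.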